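The compounds below may be only part of what the source reports. "The series", "measured", "known", "first", "only" and "open" are said of these compounds alone.

Measured in a functional assay on DU-145 cells (Homo sapiens) for cytotoxicity, read by MTT assay, with a stated time of 48 h; a higher number here means a weaker inhibitor, a lower number a stronger inhibitor:
- compound 1 `CC1(C)CCCC2=CC=C(C=O)CC[C@]21C`: 191000 nM
- compound 2 `C=C1CCC[C@]2(C)CCC(c3cn(-c4cccc([N+](=O)[O-])c4)nn3)=CC[C@@]12C`: 62500 nM
- compound 3 `C=C1CCC[C@]2(C)CCC(c3cn(CC(=O)Nc4ccc(C)cc4)nn3)=CC[C@@]12C`: 254000 nM

Compound 2 holds the lowest of these three numbers, at 62500 nM. Its gaps to compound 1 and to compound 3 both lie beyond the scatter, and the gap to compound 3 is the wider of the two. All three numbers are high on the scale of this read-out, so the series offers only a narrow view of what changes the cytotoxicity.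

The next compound to be measured is compound 4 `C=C1CCC[C@]2(C)CCC(c3cn(-c4ccc(C)cc4)nn3)=CC[C@@]12C`, which keeps the core of compound 2 and changes one group: 4-methylphenyl in place of 3-nitrophenyl on an aromatic nitrogen. The 4-methylphenyl stands in place of the 3-nitrophenyl on an aromatic nitrogen of a five-membered aromatic ring with 3 nitrogen.

Among the compounds with values here, no two measured compounds differ in one place only, so no measured step guides this change. A modest step toward a higher number in this assay is expected, because compound 2 at 62500 nM already stands at the low end of the series. Compound 3 at 254000 nM gives a rough upper reference for the range. The estimated step is a 2.2-fold higher number from compound 2 to compound 4 (0.35 log units; beyond the scatter), only slightly beyond the scatter. For compound 4 the expected value is 140000 nM, with an estimated range from 60000 nM to 300000 nM.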

Compound 4, half-maximal inhibitory concentration: 132000 nM
Estimate against measurement, compound 4: 1.1-fold (0.03 log units) above, and the stated range covers the measured number.
By their numbers in this assay, from the lowest: compound 2; then compounds 4, 1 and 3 (each within the scatter of the next).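

This position on an aromatic nitrogen now has its first single-place comparison: in this assay, 4-methylphenyl in place of 3-nitrophenyl gives a 2.1-fold higher number from compound 2 to compound 4 (0.32 log units; beyond the scatter), a modest step that lies beyond the scatter. The number therefore responds to this exchange, but the exchange alters the substituent and where it sits on the phenyl ring together, and the counts also shift from 2 hydrogen-bond acceptors in the leaving group to 0 in the entering one, so this single step cannot assign the change to any one of these differences. No supporting measurement bears on why the number moves at this position.

Still open, on these data alone, is how a plain phenyl would stand against compound 2 and compound 4, which would give a reference for reading each substituent separately. A phenyl carrying an amine or a carboxylic acid at this position would also show whether the number can move further in either direction, since a single step gives neither the range nor the direction of a trend.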